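An ethoxy analogue carrying the piperidinyl side chain

The source may hold more compounds than are shown below. What is called first, only, known or untested is meant among the compounds shown, and "the series" means these compounds.

Of the compounds shown here, two with a shared core have been measured in a physicochemical assay for solubility, in the presence of a further agent that is not named here; on this read-out lower numbers stand for lower solubility and higher numbers for higher solubility. Compound 1 `COc1ccc2c(c1)[n+]([O-])c(NCCN1CCCCC1)n[n+]2[O-]` gives 45000000 nM. Compound 2 `CCOc1ccc2c(c1)[n+]([O-])c(NCCN(C)C)n[n+]2[O-]` is reported only as > 50000000 nM, a limit of the assay rather than a number. That compound 2 stands at this limit is recorded as the limit of > 50000000 nM in this assay, at which 1 of the 2 values shown sits. Compound 3 `CCOc1ccc2c(c1)[n+]([O-])c(NCCN1CCCCC1)n[n+]2[O-]` has not yet been measured in this assay. It differs from compound 2 by piperidin-1-yl in place of dimethylamino on a saturated chain carbon, two bonds along the chain from a nitrogen on an aromatic ring, in words piperidin-1-yl in place of dimethylamino on a saturated chain carbon, two bonds along the chain from a nitrogen on an aromatic ring. Among the compounds with values here, no measured pair shows this change on its own, so its size is not known from the data. The step from compound 2 to compound 3 is expected to be an at least 1.2-fold lower number from compound 2 to compound 3 (0.09 log units; that floor lies within the scatter), a move from a limit that need not exceed the usual scatter. Compound 3 is estimated at 40000000 nM, with a range from 15000000 nM to 60000000 nM.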

Compound 3, solubility: > 49000000 nM
Compound 3: no number, only a limit; the forecaster's own chance of this, stated with the estimate: 35%; middle value at least 1.2-fold (0.08 log units) away from the limit.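

In this assay compound 3 is reported only as a limit, > 49000000 nM. Compound 2 is also reported only as a limit, > 50000000 nM, and with a limit at both ends, the step from dimethylamino to piperidin-1-yl on the chain cannot be read. The other change, methyl in place of hydrogen on a saturated chain carbon bound to an oxygen on an aromatic ring, can be read only as a floor: it gives an at least 1.0-fold higher number from compound 1 to compound 3 (0.03 log units; that floor lies within the scatter), which shows no change beyond the scatter.

From the compounds shown here alone, the true size of both changes stays open, since neither ethoxy compound has a number in this assay. Also open, going by these compounds, is what a morpholin-4-yl group in place of piperidin-1-yl, or a propoxy group in place of ethoxy, would give.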